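This account rests on a few compounds, and the source may have more. Where it says the series, first, only, none or still open, it means among the compounds named here.

In a functional assay on MIA PaCa-2 cells (Homo sapiens) for antiproliferative activity, read by MTT assay, with a stated time of 48 h (on this read-out lower numbers stand for stronger inhibition and higher numbers for weaker inhibition), compound 2 `CCCCCCCc1nc(N)n(CC(=O)Nc2ccccc2)c1-c1ccccc1Br` gives 7900 nM, the second highest of the three numbers. Compound 1 `CCCCCCc1nc(N)n(CC(=O)Nc2ccccc2)c1-c1ccccc1Br` gives 8600 nM and compound 3 `Nc1nc(Cc2ccccc2)c(-c2ccccc2Br)n1CC(=O)Nc1ccccc1` gives 5700 nM, both within the scatter of compound 2. Compound 4 `Cc1ccc(Cc2nc(N)n(CC(=O)Nc3ccccc3)c2-c2ccccc2Br)cc1` differs from compound 2 by 4-methylphenyl in place of hexyl on a saturated chain carbon bound to an aromatic carbon. The measured steps that bear on this change are a 1.4-fold lower number from compound 2 to compound 3 (0.14 log units; within the scatter) and a 1.5-fold lower number from compound 1 to compound 3 (0.18 log units; within the scatter), where phenyl in place of hexyl or pentyl on the same carbon left the numbers within the scatter. The step to compound 4 is therefore expected to stay within the scatter as well, a 1.4-fold lower number from compound 2 to compound 4 (0.16 log units; within the scatter). Compound 4 is estimated at 5500 nM, with a range from 2500 nM to 12000 nM.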

Compound 4, half-maximal inhibitory concentration: 9200 nM
The estimate for compound 4 lay 1.7-fold (0.22 log units) below the measured number; the measured number falls inside the stated range.
By their numbers in this assay, from the lowest: compounds 3, 2, 1 and 4 (each within the scatter of the next).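

In this assay, 4-methylphenyl on this saturated chain carbon cannot be told apart from hexyl (a 1.2-fold higher number from compound 2 to compound 4 (0.07 log units; within the scatter)) or from pentyl (a 1.1-fold higher number from compound 1 to compound 4 (0.03 log units; within the scatter)). For the compounds shown here, the methyl on an aromatic carbon, a change the earlier compounds did not include, also stays within the scatter (a 1.6-fold higher number from compound 3 to compound 4 (0.21 log units; within the scatter)). No evidence is available that bears on this result. The compounds shown leave open whether an amine or a carboxylic acid in place of that methyl, or a much longer chain on the same carbon, would move the number beyond the scatter.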